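A few compounds are considered here, and "the series" means these few. Any claim that something is new, unique, unknown or untested is made for them only; others in the source may bear on it.

Measured so far in a functional assay on MCF7 cells (Homo sapiens) for antiproliferative activity, read by MTT assay, with a stated time of 72 h; on this read-out lower numbers stand for stronger inhibition and higher numbers for weaker inhibition:
compound 1 `CCCSc1nc(N/N=C/c2cc(OC)c(OC)c(OC)c2)c2nnn(Cc3ccccc3)c2n1` gives only a limit, > 64000 nM.
compound 2 `CCCSc1nc(N/N=C/c2ccc([N+](=O)[O-])cc2)c2nnn(Cc3ccccc3)c2n1` gives 11000 nM.
compound 3 `COc1cc(/C=N/Nc2nc(SCc3ccccc3)nc3c2nnn3Cc2ccccc2)cc(OC)c1OC` gives 13500 nM.

Compound 2 and compound 3 sit within the scatter of each other; the third value is a limit (the limit of > 64000 nM in this assay, at which 1 of the 3 values shown sits). Compound 4 `CCCSc1nc(N/N=C/c2ccccc2)c2nnn(Cc3ccccc3)c2n1` differs from compound 2 by hydrogen in place of nitro on an aromatic carbon. Within the data shown here, the only measured step, an at least 4.7-fold lower number from compound 1 to compound 3 (0.67 log units; beyond the scatter), concerns the chain on the sulfur, not the aryl substituent, so it does not bear directly on this change. Compound 1, with its trimethoxyphenyl, gives only a limit. Compound 2 gives a number. Among the measured compounds shown here, no measured pair isolates the nitro itself, so the expectation is uncertain and leans toward a weaker number. For compound 4 the estimate is 25000 nM, within 8000 nM to 80000 nM. The expected step is a 2.3-fold higher number from compound 2 to compound 4 (0.36 log units; beyond the scatter).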

Compound 4, half-maximal inhibitory concentration: > 64000 nM
Compound 4: a limit, no number; the forecaster's own chance of this, stated with the estimate: 30%; at least 2.5-fold (0.40 log units) between middle value and limit.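

In this assay, among these compounds, this is the first pair to isolate the aryl substituent, and losing the nitro weakens inhibition: the step reads an at least 5.8-fold higher number from compound 2 to compound 4 (0.76 log units; beyond the scatter). Compound 4 gives only a limit, so the full size of this step cannot be read. Among the compounds shown, only the trimethoxyphenyl compound 1 shares this limit: the limit of > 64000 nM in this assay, at which 2 of the 4 values shown sit.

On these data alone, whether this effect is specific to nitro remains open, and a nitrile or an amine on the same aromatic carbon would help to separate the two possibilities. Also open, as far as these compounds go, is how the 4-nitrophenyl behaves with the sulfur chain of compound 3.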